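Cytotoxicity across a shared core with varied side chains

The source may report more compounds than this note shows. Statements on the series, on what has been measured and on what is new or still open speak of the compounds shown alone.

Three compounds of a shared core have been examined in an ADME assay on cells (Homo sapiens) for cytotoxicity, read by polymerase chain reaction, with a stated time of 3 days; a lower number here means that less compound is tolerated, a higher number that more compound is tolerated. Compound 1 `Nc1nc(Cl)c(-c2ncco2)c(N[C@@H]2C[C@H](CO)[C@@H](O)[C@H]2O)n1` reaches only a limit in this assay, > 25000 nM, which is a boundary of the measurement and not a number. Compound 2 `CNc1ccc2nc(-c3c(Cl)nc(N)nc3N[C@@H]3C[C@H](CO)[C@@H](O)[C@H]3O)sc2c1` gives 6000 nM in this assay. Compound 3 `CCNc1nc(C)c(-c2nc3ccccc3s2)c(N[C@@H]2C[C@H](CO)[C@@H](O)[C@H]2O)n1` gives 12000 nM in this assay, and the value of compound 2 sits within the usual scatter of that number, so the two cannot be told apart. Compound 4 `Cc1nc(NCc2cccnc2)nc(N[C@@H]2C[C@H](CO)[C@@H](O)[C@H]2O)c1-c1nc2ccccc2s1` has not yet been tested in this assay. It differs from compound 3 in one place: pyridin-3-yl in place of methyl on a saturated chain carbon bound to a nitrogen on an aromatic ring. Within the data shown here, no pair of measured compounds shows this change, so its size cannot be read from the numbers in hand. Given that compound 3 gives 12000 nM in this assay and that the other numbered value lies within its scatter, the step from compound 3 to compound 4 is expected to be small, a 1.2-fold lower number from compound 3 to compound 4 (0.08 log units; within the scatter), in no clear direction. Compound 4 is therefore estimated to give about 10000 nM in this assay, expected between 4000 nM and 25000 nM.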

Compound 4, half-maximal cytotoxic concentration: 5000 nM
For compound 4 the middle estimate is 2.0-fold (0.30 log units) above the measured one; low and high end bracket the measured number.
By their numbers in this assay, from the lowest: compounds 4, 2 and 3 (each within the scatter of the next, the first and the last beyond it). At a limit, above all of these: compound 1.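

Among these compounds, putting pyridin-3-yl in place of methyl on a saturated chain carbon bound to a nitrogen on an aromatic ring gives a 2.4-fold lower number from compound 3 to compound 4 (0.38 log units; beyond the scatter) in this assay as the first step whose size can be read. The earlier compounds shown here held no pair differing in one place, and this step shows that the position is not silent in this assay, although the change in the number stays modest for a group this much larger. Nothing measured here bears on why the number moves.

The compounds shown leave open whether the ring nitrogen of pyridin-3-yl matters, which a plain phenyl group in the same place would test, and whether a longer chain without a ring would do the same. They also leave open whether this change would carry over to other members of the shared core.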